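Chain Shortening on a Thienopyrimidine Urea Series: Compound 4

This account rests on a few compounds, and the source may have more. Where it says the series, first, only, none or still open, it means among the compounds named here.

Measured in a functional assay on NCI-H460 cells (Homo sapiens) for cytotoxicity, read by MTT assay, with a stated time of 72 h; a lower number here means a stronger inhibitor, a higher number a weaker inhibitor:
compound 1 `CCN(CC)CCCNc1nc(-c2ccc(NC(=O)Nc3ccc(F)cc3)cc2)nc2c(Cl)c(Cl)sc12` gives 450 nM
compound 2 `CCN(CC)CCCNc1nc(-c2ccc(NC(=O)Nc3ccccc3F)cc2)nc2ccsc12` gives 370 nM
compound 3 `CCN(CC)CCNc1nc(-c2ccc(NC(=O)Nc3ccc(F)cc3)cc2)nc2c(Cl)c(Cl)sc12` gives 500 nM

The three values in this assay lie close together. Compound 1 and compound 3 share a core and differ only by diethylamino in place of (diethylamino)methyl on a saturated chain carbon, two bonds along the chain from a nitrogen on an aromatic ring; this change gave a 1.1-fold higher number from compound 1 to compound 3 (0.05 log units; within the scatter). Compound 2 differs from compound 1 in its core, and that difference is not broken down here.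

Compound 4 `CCN(CC)CCNc1nc(-c2ccc(NC(=O)Nc3ccccc3F)cc2)nc2ccsc12` is not yet measured. It stands to compound 2 as compound 3 stands to compound 1: the change is diethylamino in place of (diethylamino)methyl on a saturated chain carbon, two bonds along the chain from a nitrogen on an aromatic ring, the same change as before. Because the earlier step was a 1.1-fold higher number from compound 1 to compound 3 (0.05 log units; within the scatter), compound 4 is expected to sit near compound 2, with an estimated step of a 1.1-fold higher number from compound 2 to compound 4 (0.03 log units; within the scatter). Compound 4 is therefore estimated at 400 nM in this assay, expected between 200 nM and 800 nM.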

Compound 4, half-maximal inhibitory concentration: 430 nM
Compound 4: the middle estimate sits 1.1-fold (0.03 log units) below what was measured; measured number inside the range.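

On the second core, diethylamino in place of (diethylamino)methyl gave a 1.2-fold higher number from compound 2 to compound 4 (0.07 log units; within the scatter) in this assay. Set beside the step on the first core, the change carried over with no difference that can be told apart: the same change on two cores in this assay, a 1.1-fold higher number (0.05 log units; within the scatter) from compound 1 to compound 3 and a 1.2-fold higher number (0.07 log units; within the scatter) from compound 2 to compound 4, 1.0-fold (0.02 log units) apart, within the scatter of two such steps. This shows that the shorter chain leaves the number within the scatter on these two cores, but it does not show the same for any other core, nor does it explain why the two steps agree.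

The compounds shown leave open whether a chain longer than 3-(diethylamino)propyl would behave alike. They also leave open what a morpholine or a carboxylic acid in place of the diethylamino group would do.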